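This account rests on a few compounds, and the source may have more. Where it says the series, first, only, none or still open, it means among the compounds named here.

Compound 1 `O=c1c2cccnc2sn1Cc1ccccc1` gives 23000 nM in an assay for inhibition of histone acetyltransferase KAT2B (Homo sapiens), read by fluorescence; on this read-out higher numbers stand for weaker inhibition and lower numbers for stronger inhibition.
Compound 2 `O=c1c2cccnc2sn1Cc1ccc(Cl)cc1` gives 17500 nM in this assay.
Compound 3 `Cc1cnc2sn(-c3ccc(Oc4ccccc4)cc3)c(=O)c2c1` gives 12900 nM in this assay.

Compound 2 holds the second highest of these three numbers. Its nearest neighbour is compound 1, and the change seen a 1.3-fold lower number from compound 1 to compound 2 (0.12 log units; within the scatter) lies within the scatter of repeated measurements. Compound 3, the furthest of the three, also sits within that scatter of compound 2, so none of the three can be ranked against the others on these data; all three compounds share the same core and differ only in the group attached to it.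

Compound 4 `Cc1ccc(Cn2sc3ncccc3c2=O)cc1` is obtained from compound 2 by a single exchange: methyl in place of chloro on an aromatic carbon. For the measured compounds named here, the only measured step that touches this position is the one from compound 1 to compound 2, where hydrogen was exchanged for chloro at the same carbon, and that step, a 1.3-fold lower number from compound 1 to compound 2 (0.12 log units; within the scatter), stayed within the scatter. With one small group replacing another at a place where the earlier exchange changed little, no step beyond the scatter is expected in this assay.

Compound 4 is therefore expected to give about 20000 nM, with a range from 9000 nM to 45000 nM. The expected step is a 1.1-fold higher number from compound 2 to compound 4 (0.06 log units; within the scatter).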

Compound 4, half-maximal inhibitory concentration: 27900 nM
Compound 4: middle estimate off by 1.4-fold (0.14 log units), on the low side, and the stated range covers the measured number.
By their numbers in this assay, from the lowest: compounds 3, 2, 1 and 4 (each within the scatter of the next, the first and the last beyond it).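

In this assay, this aromatic carbon, para to a large group, has now carried three different substituents: hydrogen, chloro and methyl. Methyl in place of chloro (a 1.6-fold higher number from compound 2 to compound 4 (0.20 log units; within the scatter)) and methyl in place of hydrogen (a 1.2-fold higher number from compound 1 to compound 4 (0.08 log units; within the scatter)) both stay within the scatter, so compounds 1, 2 and 4 cannot be ranked against one another, and none of the single-atom exchanges at this carbon has yet produced a step that can be told apart from repeat-measurement noise. No other information at hand bears on this result.

The compounds shown leave open whether a different kind of group at this carbon, such as an amine, a carboxylic acid or a longer chain, would give a step beyond the scatter. Going by these compounds, compound 3 differs from compounds 1, 2 and 4 in more than one place, so what each of its groups contributes on its own also remains open.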